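This account rests on a few compounds, and the source may have more. Where it says the series, first, only, none or still open, it means among the compounds named here.

Three compounds share one core and were tested in a functional assay (spleen, spleen) for activation, with Mus musculus as the target; a higher number here means that more compound is needed for the effect, a lower number that less compound is needed. Compound 1 `CCCCCOc1nc(N)c2nc(O)n(Cc3ccccc3)c2n1` gives 0.01 uM, compound 2 `CCNc1nc(N)c2nc(O)n(Cc3ccccc3)c2n1` gives 1 uM, and compound 3 `Nc1nc(N)c2nc(O)n(Cc3ccccc3)c2n1` gives 10 uM, the highest number of the three; every step away from it is beyond the scatter.

For the measured compounds named here, two steps bear on the new compound. The step of a 1000-fold higher number from compound 1 to compound 3 (3.00 log units; beyond the scatter) shows how much more material is needed once amino sits where pentyloxy sat. The step of a 100-fold higher number from compound 1 to compound 2 (2.00 log units; beyond the scatter) points the same way for ethylamino, and a 10-fold higher number from compound 2 to compound 3 (1.00 log units; beyond the scatter) adds a smaller rise when the ethyl is lost.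

Compound 4 `CCCOc1nc(N)c2nc(O)n(Cc3ccccc3)c2n1` carries a change of the kind (propoxy in place of amino on an aromatic carbon). Propoxy is related to the pentyloxy of compound 1, so the step is expected to run opposite to the large rise seen for compound 3 against compound 1, although the shorter chain may not recover the whole distance. Compound 4 is therefore expected to give a much lower number, around 0.03 uM with a range from 0.005 uM to 0.2 uM, an expected step of a 330-fold lower number from compound 3 to compound 4 (2.52 log units; beyond the scatter).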

Compound 4, minimum effective concentration: 0.01 uM
Compound 4: middle estimate off by 3.0-fold (0.48 log units), on the high side; the measured number falls inside the stated range.
By their numbers in this assay, from the lowest: compounds 1 and 4 (each within the scatter of the next); then compound 2; then compound 3.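

In this assay, propoxy in place of amino gives a 1000-fold lower number from compound 3 to compound 4 (3.00 log units; beyond the scatter), and propoxy in place of ethylamino gives a 100-fold lower number from compound 2 to compound 4 (2.00 log units; beyond the scatter), so the large drop seen earlier with pentyloxy is not unique to that one chain. Shortening pentyloxy to propoxy gives no change at the digits printed from compound 1 to compound 4 (within the scatter), meaning that these two chains cannot be told apart in this read-out. No measurement shown explains this behaviour at the position.

Compound 2 and compound 4 differ in both the atom joining the chain to the core and the chain itself, so propylamino would be needed to separate those two changes. From the compounds shown here alone, it also remains open whether methoxy, which is shorter than propoxy, or decyloxy, which is longer than pentyloxy, would keep the number this low.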